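Amide-nitrogen aryl swap: from compound 2 to compound 3

A few compounds are considered here, and "the series" means these few. Any claim that something is new, unique, unknown or untested is made for them only; others in the source may bear on it.

Measured so far:
- compound 1, `NCc1csc(NC(=O)c2cc3ccccc3n2Cc2ccccc2)n1`: in a physicochemical assay for lipophilicity, read by HPLC, at pH 7.4 (on this read-out higher numbers stand for higher lipophilicity and lower numbers for lower lipophilicity), compound 1 gives 3
- compound 2, `Cc1csc(NC(=O)c2cc(C(C)(C)C)nn2Cc2ccccc2)n1`: in this assay compound 2 gives 4.7

Compound 2 stands highest of the two numbers in this assay; its nearest neighbour is compound 1, whose reading lies lower by a gap beyond the usual scatter. For the measured compounds named here, the two differ in more than one place, so no single step can be drawn between them; their values show only that the core of compound 2 carries the higher reading.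

Compound 3, `CC(C)(C)c1cc(C(=O)Nc2ccncc2)n(Cc2ccccc2)n1`, has not yet been measured in this assay. It differs from compound 2 in one place: pyridin-4-yl in place of 4-methyl-1,3-thiazol-2-yl on an amide-type nitrogen.

Going by the values given here, since no step between measured compounds is available for this change, the expectation rests on the structural change alone. In this assay compound 3 is expected to read lower than compound 2, by a step of a number 1.00 log units lower from compound 2 to compound 3 (beyond the scatter), which would be beyond the scatter. The estimate for compound 3 in this assay is 3.7, within a range from 3 to 4.4.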

Compound 3, distribution coefficient: 4
The estimate for compound 3 lay 0.30 log units below the measured number; measured number inside the range.
By their numbers in this assay, from the lowest: compound 1; then compound 3; then compound 2.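

In this assay, for the compounds shown here, pyridin-4-yl in place of 4-methyl-1,3-thiazol-2-yl on an amide-type nitrogen gives a number 0.70 log units lower from compound 2 to compound 3 (beyond the scatter) as the only single-place step so far. The comparison between compound 1 and compound 2 could not isolate any one place, whereas this step shows that the reading responds to the group at this position with the rest of compound 2 held constant. Nothing measured here accounts for the size or direction of the step.

Going by these compounds, it remains open whether the same swap would give a similar step on another core, such as the core of compound 1. Also open, on these data alone, is how other groups on this amide-type nitrogen would read, for example an unsubstituted 1,3-thiazol-2-yl or a phenyl carrying a carboxylic acid.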